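A few compounds are considered here, and "the series" means these few. Any claim that something is new, unique, unknown or untested is made for them only; others in the source may bear on it.

Measured so far:
Compound 1, `Cn1c(-c2ccccc2C(F)(F)F)nnc1C12CCC(COc3ccc(S(C)(=O)=O)cc3)(CC1)CC2`. In an assay on CHO-K1 cells for inhibition of 11-beta-hydroxysteroid dehydrogenase type 2 (Mus musculus), read by scintillation proximity assay (a higher number here means a weaker inhibitor, a lower number a stronger inhibitor), compound 1 gives > 4000 nM, which is a limit of the assay and not a number.
Compound 2, `Cn1c(-c2ccccc2C(F)(F)F)nnc1C12CCC(CNS(C)(=O)=O)(CC1)CC2`. In this assay compound 2 gives > 4000 nM, again only a limit.
Compound 3, `CCS(=O)(=O)CCC12CCC(c3nnc(-c4ccccc4Br)n3C)(CC1)CC2`. In this assay compound 3 gives > 4000 nM, also a limit.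

Compound 2 therefore stands at the limit (the limit of > 4000 nM in this assay, at which 3 of the 3 values shown sit), where every value shown sits; on the numbers in hand it cannot be placed stronger or weaker than compound 1 or compound 3. Among the measured compounds shown here, the single step between measured compounds at the same position, a step that the two limits leave unreadable from compound 1 to compound 2, has no readable size, since both of its ends are limits.

The change now followed is ((tert-butyl)sulfonyl)methyl in place of methanesulfonamido on a saturated chain carbon bound to a saturated ring carbon, giving compound 4, `Cn1c(-c2ccccc2C(F)(F)F)nnc1C12CCC(CCS(=O)(=O)C(C)(C)C)(CC1)CC2`. For the measured compounds named here, no measured step bears on it with a readable size; the only neighbouring step is itself unreadable. With all three values at the limit and nothing to point to a shift, no step beyond the scatter is expected in either direction in this assay. The step that the limit leaves unreadable from compound 2 to compound 4 is estimated as nil within scatter. Compound 4 is expected at 6000 nM, with a range from 1500 nM to 25000 nM, and most probably the assay again reports only a limit.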

Compound 4, half-maximal inhibitory concentration: > 4000 nM
Compound 4: only a limit was reported (the forecaster's own chance of this, stated with the estimate: 80%); the middle value lies beyond the limit too.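

The steps to compound 4 from compound 2 and from compound 1 cannot be read, since both ends of each step are limits and not numbers: the limit of > 4000 nM in this assay, at which 4 of the 4 values shown sit.

The compounds shown leave open whether any change on the shared core shifts inhibition in this assay at all, and how strong any of these compounds actually is.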